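Lengthening the Acid Chain on Two Related Cores

The compounds below may be only part of what the source reports. "The series", "measured", "known", "first", "only" and "open" are said of these compounds alone.

Compound 1 `O=C(O)CCCCCCCCCn1nc(-c2ccccc2)c(-c2ccccc2)c1-c1ccccc1`: in a functional assay for inhibition, with Homo sapiens as the target (on this read-out lower numbers stand for stronger inhibition and higher numbers for weaker inhibition), compound 1 gives 5500 nM.
Compound 2 `O=C(O)CCCCCCCCCCn1nc(-c2ccccc2)c(-c2ccccc2)c1-c1ccccc1`: compound 2 gives 18600 nM.
Compound 3 `O=C(O)CCCCCCCn1cc(-c2ccccc2)c(-c2ccccc2)n1`: compound 3 gives only a limit of the assay, > 85000 nM.

Compound 2 differs from compound 1 by carboxymethyl in place of carboxy on a saturated chain carbon, nine bonds along the chain from an aromatic nitrogen, and that step is a 3.4-fold higher number from compound 1 to compound 2 (0.53 log units; beyond the scatter). Compound 4 `O=C(O)CCCCCCCCn1cc(-c2ccccc2)c(-c2ccccc2)n1` is still unmeasured and differs from compound 3 by carboxymethyl in place of carboxy on a saturated chain carbon, seven bonds along the chain from an aromatic nitrogen. This is the same kind of change, though the place differs: nine bonds along the chain from an aromatic nitrogen in the first pair, seven bonds along the chain from an aromatic nitrogen in the second. How the core of compound 3 differs from the core of compound 1 is not broken down here. Since compound 3 sits at the limit of > 85000 nM in this assay, at which 1 of the 3 values shown sits, the expected step can only be read as staying at or beyond that limit. Compound 4 is expected to give about 150000 nM in this assay, between 60000 nM and 400000 nM. That expectation means a step that the limit leaves unreadable from compound 3 to compound 4, most likely reported as a limit again.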

Compound 4, half-maximal inhibitory concentration: 4500 nM
Compound 4: the middle estimate sits 33-fold (1.52 log units) above what was measured; measured number below the stated range.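

In this assay, carboxymethyl in place of carboxy gives an at least 18-fold lower number from compound 3 to compound 4 (1.27 log units; beyond the scatter), so this change does not carry over from one core to the other and here runs the opposite way: the same change on two cores in this assay, a 3.4-fold higher number (0.53 log units; beyond the scatter) from compound 1 to compound 2 and an at least 18-fold lower number (1.27 log units; beyond the scatter) from compound 3 to compound 4, at least 63-fold (1.80 log units) apart, beyond the scatter of two such steps

Compound 3 gives > 85000 nM, which is a limit of the assay and not a number, so the size of this step is known only in part. The two pairs differ both in their core and in the place of the change, so these data do not show which of the two sets the direction of the step.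

The compounds shown leave open whether a longer chain on the core of compound 4 would keep the lower number or lose it. They also leave open how a shorter chain would behave on the core of compound 1.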